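Cytotoxicity notes on a chromone acrylamide pair

The source may report more compounds than this note shows. Statements on the series, on what has been measured and on what is new or still open speak of the compounds shown alone.

Measured so far:
compound 1, `Cc1ccccc1NC(=O)/C=C/c1coc2cc(O)ccc2c1=O`: 374000 nM
compound 2, `COc1ccc(CNC(=O)/C=C/c2coc3cc(OC)ccc3c2=O)cc1`: 43000 nM

Both compounds were read in an ADME assay on HepG2 2.2.15 cells (Homo sapiens) for cytotoxicity, read by MTT assay, with stated times of 48 h and 9 days; a lower number here means that less compound is tolerated, a higher number that more compound is tolerated. Compound 1 gives 374000 nM, while compound 2 gives 43000 nM. Compound 2 therefore holds the lower of the two numbers, and the gap to compound 1 lies beyond the scatter, so compound 2 is the less tolerated of the pair on the numbers at hand. Within the data shown here, the two differ in more than one place, so no single step is drawn between them.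

Compound 3, `COc1ccc2c(=O)c(/C=C/C(=O)NCc3ccc(F)cc3F)coc2c1`, follows from compound 2 by one change: 2,4-difluorophenyl in place of 4-methoxyphenyl on a saturated chain carbon bound to an amide-type nitrogen. The amide, the acrylate linker and the core of compound 2 are kept unchanged; only the aryl group on the benzylic carbon is exchanged.

Among the measured compounds shown here, no measured step of this kind exists, so the direction in this assay is open. With compound 2 at 43000 nM as the only anchor, the expectation is that compound 3 stays close, with any step from compound 2 to compound 3 of a 1.2-fold higher number from compound 2 to compound 3 (0.07 log units; within the scatter) falling within the scatter. Compound 3 is thus estimated at 50000 nM, with a range from 15000 nM to 160000 nM.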

Compound 3, half-maximal cytotoxic concentration: 79300 nM
Estimate against measurement, compound 3: 1.6-fold (0.20 log units) below; the range from low to high includes it.
By their numbers in this assay, from the lowest: compounds 2 and 3 (each within the scatter of the next); then compound 1.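

This position now has its first single-place step: in this assay, 2,4-difluorophenyl in place of 4-methoxyphenyl on a saturated chain carbon bound to an amide-type nitrogen gives (a 1.8-fold higher number from compound 2 to compound 3 (0.27 log units; within the scatter)), so compound 2 and compound 3 cannot be told apart on these numbers. The exchange replaces a group with 1 hydrogen-bond acceptor by one with 0 hydrogen-bond acceptors at the same count of 8 heavy atoms, and this position accepts that swap without a separation beyond the scatter, which the earlier pair could not show because its members differ in more than one place. Nothing measured here bears on why the two numbers lie so close.

On these data alone, it remains open whether a group of another kind at this position, such as an aminomethyl-substituted phenyl, a carboxylic acid on the phenyl ring or a 2-phenylethyl chain in place of the benzyl group, would give a step beyond the scatter. Also open, as far as these compounds go, is how the fluorine atoms and the methoxy group each count alone, and which of the several differences separates compound 1 from the other two compounds.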